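This account rests on a few compounds, and the source may have more. Where it says the series, first, only, none or still open, it means among the compounds named here.

Measured so far:
Compound 1, `Cc1ccc(C(=O)NN2C(=O)NC3(CC3(C)C)C2=O)cc1`: 100 mg/kg
Compound 2, `CC1(C)CC12NC(=O)N(NC(=O)c1ccc(C(F)(F)F)cc1)C2=O`: 30 mg/kg
Compound 3, `CC1(C)CC12NC(=O)N(NC(=O)c1ccc([N+](=O)[O-])cc1)C2=O`: 300 mg/kg

In a functional assay on the whole organism (Hindlimb) for inhibition, with Mus musculus as the target, with a stated time of 0.5 h (on this read-out lower numbers stand for an effect already at smaller amounts and higher numbers for an effect only at larger amounts of compound), compound 3 gives the highest of the three numbers, its nearest neighbour being compound 1 and its furthest compound 2. Compound 4, `COc1ccc(C(=O)NN2C(=O)NC3(CC3(C)C)C2=O)cc1`, differs from compound 3 in one place: methoxy in place of nitro on an aromatic carbon. Among the compounds with values here, no measured pair swaps nitro for methoxy, so the steps that bear on it are those leading into the nitro compound, a 3.0-fold higher number from compound 1 to compound 3 (0.48 log units; beyond the scatter) and a 10-fold higher number from compound 2 to compound 3 (1.00 log units; beyond the scatter), both of which raised the number beyond the scatter. Leaving the nitro group is therefore expected to lower the number in this assay, by about the size of a 3.0-fold lower number from compound 3 to compound 4 (0.48 log units; beyond the scatter). Compound 4 is estimated at 100 mg/kg, within 30 mg/kg to 300 mg/kg.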

Compound 4, minimum effective dose: 100 mg/kg
Compound 4: middle estimate and measured number agree at the digits printed; the measured number falls inside the stated range.
By their numbers in this assay, from the lowest: compound 2; then compounds 1 and 4 (each within the scatter of the next); then compound 3.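

In this assay, methoxy on this aromatic carbon, para to a large group, cannot be told apart from methyl (no change at the digits printed from compound 1 to compound 4 (within the scatter)). Methoxy in place of nitro helps (a 3.0-fold lower number from compound 3 to compound 4 (0.48 log units; beyond the scatter)), whereas methoxy in place of trifluoromethyl costs about as much (a 3.3-fold higher number from compound 2 to compound 4 (0.52 log units; beyond the scatter)), so trifluoromethyl keeps the lowest number and nitro the highest. Nothing available here explains these differences.

From the compounds shown here alone, how an amine or a carboxylic acid would read at this position remains open. So does whether a longer chain, such as ethoxy, would match methoxy.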